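Chloro on the phenyl ring of a tricyclic scaffold

The source may hold more compounds than are shown below. What is called first, only, known or untested is meant among the compounds shown, and "the series" means these compounds.

Measured compounds: compound 1 `Cc1nn(C)c2c1C(c1ccccc1)=NCCN2` gives 2.5 mg/kg in a functional assay on the whole organism for positive allosteric modulation, with Rattus norvegicus as the target; a higher number here means that more compound is needed for the effect, a lower number that less compound is needed; compound 2 `Cc1nn(C)c2c1C(c1ccccc1)=NCCN2C` gives 2.5 mg/kg in this assay.

Compound 1 stands level with compound 2 at the digits shown. Among the compounds with values here, the only measured step, no change at the digits printed from compound 1 to compound 2 (within the scatter), concerns a methyl entering on a ring nitrogen of the shared core and lies within the scatter.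

Compound 3 `Cc1nn(C)c2c1C(c1cccc(Cl)c1)=NCCN2` differs from compound 1 by chloro in place of hydrogen on an aromatic carbon. Within the data shown here, no measured step touches this part of the molecule, so nothing among the measured compounds points to a change in either direction. The step from compound 1 to compound 3 is therefore expected to be no change at the digits printed from compound 1 to compound 3 (within the scatter), that is, no change beyond the scatter. For compound 3 the expected minimum effective dose in this assay is 2.5 mg/kg, with an estimated range of 1 mg/kg to 6 mg/kg.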

Compound 3, minimum effective dose: 0.63 mg/kg
The estimate for compound 3 lay 4.0-fold (0.60 log units) above the measured number, outside the stated range (below it).
By their numbers in this assay, from the lowest: compound 3; then compounds 1 and 2 (each within the scatter of the next).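

In this assay, the aromatic ring of carbon only responds to a single substitution: chloro in place of hydrogen, meta to a large group, gives a 4.0-fold lower number from compound 1 to compound 3 (0.60 log units; beyond the scatter), so less compound is needed for the effect. The earlier step, no change at the digits printed from compound 1 to compound 2 (within the scatter), concerned a ring nitrogen of the shared core and did not show this, which makes the aromatic carbon the first place in the series where a change of one heavy atom moves the minimum effective dose beyond the scatter. Nothing at hand explains why the chloro compound needs a lower dose.

As far as these compounds go, it remains open whether fluoro, methoxy or an amine at this same place would lower the dose as well. From the compounds shown here alone, it is also open whether chloro would have the same effect at another carbon of this ring, or together with the methyl on the ring nitrogen of compound 2.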